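Hydroxy for Methoxy on a Second Urea Pair

The source may hold more compounds than are shown below. What is called first, only, known or untested is meant among the compounds shown, and "the series" means these compounds.

Compound 1 `COc1cc(-c2nn(-c3cccc(NC(=O)Nc4cc(C(F)(F)F)cc(C(F)(F)F)c4)c3)cc2-c2ccncc2)ccc1Cl` and compound 2 `O=C(Nc1cccc(-n2cc(-c3ccncc3)c(-c3ccc(Cl)c(O)c3)n2)c1)Nc1cc(C(F)(F)F)cc(C(F)(F)F)c1` differ in one place only: hydrogen in place of methyl on an oxygen on an aromatic ring. In a functional assay on HCT-116 cells (Homo sapiens) for inhibition, read by sulforhodamine B assay, with a stated time of 48 h (on this read-out lower numbers stand for higher toxicity in this test and higher numbers for lower toxicity in this test), compound 1 gives 4830 nM, and compound 2 gives 2650 nM; the step is a 1.8-fold lower number from compound 1 to compound 2 (0.26 log units; within the scatter), so the two numbers cannot be told apart with confidence. Compound 3 `COc1cc(-c2nn(-c3cccc(NC(=O)Nc4ccc(Cl)c(C(F)(F)F)c4)c3)cc2-c2ccncc2)ccc1Cl` carries a different urea aryl group; how the core of compound 3 differs from the core of compound 1 is not broken down here. In this assay compound 3 gives 21500 nM, the highest of the three numbers, standing beyond the scatter from both compound 1 and compound 2. Compound 4 `O=C(Nc1cccc(-n2cc(-c3ccncc3)c(-c3ccc(Cl)c(O)c3)n2)c1)Nc1ccc(Cl)c(C(F)(F)F)c1` has not been measured. It relates to compound 3 exactly as compound 2 relates to compound 1, by the same change at the same place: hydrogen in place of methyl on an oxygen on an aromatic ring. Against this background a step of a 1.5-fold lower number from compound 3 to compound 4 (0.19 log units; within the scatter) is expected for compound 4, resting on the earlier step of a 1.8-fold lower number from compound 1 to compound 2 (0.26 log units; within the scatter), which was small. In this assay compound 4 is therefore estimated at 14000 nM, with a plausible range from 6000 nM to 30000 nM.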

Compound 4, concentration lethal to 50% of the cells: > 32500 nM
Compound 4 ended at the assay's limit; the forecaster's own chance of this, stated with the estimate: 5%; middle value at least 2.3-fold (0.36 log units) away from the limit.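

In this assay compound 4 stands at > 32500 nM, which is a limit of the assay and not a number: the limit of > 32500 nM in this assay, at which 1 of the 4 values shown sits. Going from methoxy to hydroxy gives an at least 1.5-fold higher number from compound 3 to compound 4 (0.17 log units; that floor lies within the scatter), and this step does not match the one seen on the core of compound 1, so the change did not carry over as a fixed increment from one core to the other: the same change on two cores in this assay, a 1.8-fold lower number (0.26 log units; within the scatter) from compound 1 to compound 2 and an at least 1.5-fold higher number (0.17 log units; that floor lies within the scatter) from compound 3 to compound 4, at least 2.7-fold (0.44 log units) apart, beyond the scatter of two such steps. This shows only that the result of the change depended on the core in these two pairs; it does not give the true size of the second step, which has only a floor, and it does not show what produces the difference or whether it would hold on any further core.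

The compounds shown leave open whether the difference between the two pairs follows the urea aryl group, since only two such groups appear. They also leave open how an ethoxy group or an amine would behave in place of the hydroxy on either core.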